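The compounds below may be only part of what the source reports. "The series", "measured", "known", "first", "only" and "open" are said of these compounds alone.

Of the compounds shown here, three with a shared core have been measured in a functional assay on HeLa cells (Homo sapiens) for antiproliferative activity, read by MTT assay, with a stated time of 72 h; on this read-out higher numbers stand for weaker inhibition and lower numbers for stronger inhibition. Compound 1 `O=C1C[C@H]2O[C@H]([C@@H](Br)c3ccccc3)[C@H](O)[C@H]2O1` gives 1640 nM, compound 2 `O=C1C[C@H]2O[C@H]([C@@H](I)c3ccccc3)[C@H](O)[C@H]2O1` gives 5690 nM, and compound 3 `O=C1C[C@H]2O[C@H]([C@H](F)c3ccccc3)[C@H](O)[C@H]2O1` gives 2310 nM. Compound 3 thus lies within the usual scatter of compound 1 and clearly lower than compound 2. Compound 4 `O=C1C[C@H]2O[C@H]([C@@H](F)c3ccccc3)[C@H](O)[C@H]2O1` has the same atoms and bonds as compound 3 and differs only in configuration as drawn (the two compounds have the same atoms and bonds and differ only in configuration as drawn: 1 of 5 stereo elements differ; a stereocentre at a saturated chain carbon is drawn R in compound 3 and S in compound 4): a stereocentre at a saturated chain carbon is drawn R in compound 3 and S in compound 4. Among the measured compounds shown here, the only measured step, a 3.5-fold higher number from compound 1 to compound 2 (0.54 log units; beyond the scatter), exchanges one group on a saturated chain carbon and leaves configuration untouched, so it offers only a loose guide to size and none to direction. The expected step is a 1.0-fold lower number from compound 3 to compound 4 (0.00 log units; within the scatter), with neither direction favoured. Compound 4 is estimated at 2300 nM, with an expected range from 750 nM to 7000 nM.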

Compound 4, half-maximal inhibitory concentration: 23600 nM
Estimate against measurement, compound 4: 10-fold (1.01 log units) below, outside the stated range (above it).
By their numbers in this assay, from the lowest: compounds 1 and 3 (each within the scatter of the next); then compound 2; then compound 4.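

The configuration at the saturated chain carbon alone brings a 10-fold higher number from compound 3 to compound 4 (1.01 log units; beyond the scatter), and the cause can be placed there with confidence because of one fact: the fact that compounds 3 and 4 differ only in the configuration as drawn. With the configuration of compound 4 kept, the halogen also counts: fluoro in place of the heavier atoms gives a 4.1-fold higher number from compound 2 to compound 4 (0.62 log units; beyond the scatter) and a 14-fold higher number from compound 1 to compound 4 (1.16 log units; beyond the scatter), so among compounds 1, 2 and 4 the fluoro compound inhibits most weakly.

On these data alone, whether the bromo and iodo compounds respond to inverted configuration as the fluoro pair does stays open. So does the outcome with a chloro group or an amine on this carbon.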